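This account rests on a few compounds, and the source may have more. Where it says the series, first, only, none or still open, it means among the compounds named here.

For the measured compounds named here, compound 3 `CCCC(=O)Nc1c(C(O)(C(F)(F)F)C(F)(F)F)ccc2ccccc12` gives 708 nM in a functional assay (Sus scrofa) with sulfonylurea receptors; K-ATP channels (Homo sapiens) as the target (on this read-out higher numbers stand for an effect only at larger amounts of compound and lower numbers for an effect already at smaller amounts), the highest of the three numbers measured so far. Compound 1 `CC(=O)Nc1c(C(O)(C(F)(F)F)C(F)(F)F)ccc2ccccc12` gives 95.5 nM, and compound 2 `CCC(=O)Nc1c(C(O)(C(F)(F)F)C(F)(F)F)ccc2ccccc12` gives 8.91 nM. The steps between them are all beyond the scatter: an 11-fold lower number from compound 1 to compound 2 (1.03 log units; beyond the scatter), a 7.4-fold higher number from compound 1 to compound 3 (0.87 log units; beyond the scatter) and a 79-fold higher number from compound 2 to compound 3 (1.90 log units; beyond the scatter). The length of the saturated chain on the carbonyl carbon therefore matters strongly, with compound 2 standing apart from compound 1 and compound 3.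

Compound 4 `C/C=C/C(=O)Nc1c(C(O)(C(F)(F)F)C(F)(F)F)ccc2ccccc12` differs from compound 3 in one place: prop-1-en-1-yl in place of propyl on a carbonyl carbon. Going by the values given here, the chain keeps the same count of carbon atoms, so none of the measured steps, which all change chain length, bears on this change directly; no measured pair shows what a double bond in the chain does. Because compound 3 gives 708 nM and the change leaves the chain length unaltered, compound 4 is expected to stay near compound 3, with the step of a 1.8-fold lower number from compound 3 to compound 4 (0.25 log units; within the scatter) estimated as within the scatter, though the range is wide. Compound 4 is estimated at 400 nM in this assay, between 60 nM and 3000 nM.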

Compound 4, half-maximal effective concentration: 49 nM
Compound 4: middle estimate off by 8.2-fold (0.91 log units), on the high side, and the stated range ends above it.
By their numbers in this assay, from the lowest: compound 2; then compounds 4 and 1 (each within the scatter of the next); then compound 3.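

In this assay, a 14-fold lower number from compound 3 to compound 4 (1.16 log units; beyond the scatter) shows that on this carbonyl carbon the read-out depends on more than the length of the chain, as propyl and prop-1-en-1-yl have the same count of carbon atoms. Prop-1-en-1-yl in place of ethyl gives a 5.5-fold higher number from compound 2 to compound 4 (0.74 log units; beyond the scatter) and so does not reach the number of the ethyl compound, while prop-1-en-1-yl in place of methyl gives a 1.9-fold lower number from compound 1 to compound 4 (0.29 log units; within the scatter) and so leaves compound 4 level with compound 1. Nothing shown here explains why the double bond has this effect.

On these data alone, whether an ethenyl group would give the same kind of shift on the shorter chain remains open. So does the response of this position to a cyclopropyl group, a prop-1-yn-1-yl group or a butyl chain.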